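Working notes: one-carbon group at the aryl carbon, compound 4

The compounds below may be only part of what the source reports. "The series", "measured", "known", "first", "only" and "open" are said of these compounds alone.

The shared core carries a variable group on an aromatic carbon of a six-membered aromatic ring of carbon only, and the three measured compounds differ only there. Compound 1 `CCCCc1nc(=O)c(S(=O)(=O)c2ccc(-c3cccnc3)cc2)c(O)n1-c1c(OC)cccc1OC` gives 88% in an ADME assay on microsomes from liver (Homo sapiens) for metabolic stability, using NADPH, with a stated time of 10 min; a higher number here means that more of the compound is left, a lower number that less of the compound is left. Compound 2 `CCCCc1nc(=O)c(S(=O)(=O)c2ccc(-c3ccc(F)nc3)cc2)c(O)n1-c1c(OC)cccc1OC` gives 100% in this assay, and compound 3 `CCCCc1nc(=O)c(S(=O)(=O)c2ccc(-n3cc(Cl)ccc3=O)cc2)c(O)n1-c1c(OC)cccc1OC` gives 94%. Compound 3 stands second highest of the three numbers: its nearest is compound 1 (a number 6 percentage points higher from compound 1 to compound 3 (within the scatter)) and its furthest is compound 2 (a number 6 percentage points lower from compound 2 to compound 3 (within the scatter)), both within the scatter. For the measured compounds named here, the one step beyond the scatter is a number 12 percentage points higher from compound 1 to compound 2 (beyond the scatter), a modest one.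

Compound 4 `CCCCc1nc(=O)c(S(=O)(=O)c2ccc(C)cc2)c(O)n1-c1c(OC)cccc1OC` differs from compound 3 in one carbon atom in place of a group of 8 heavy atoms (5 carbon, 1 nitrogen, 1 oxygen, 1 chlorine; one six-membered aromatic ring with 1 hetero atom), on an aromatic carbon. Going by the values given here, no measured step puts a single carbon at this carbon, so the steps that bear on it are the exchanges of one ring group for another at the same place, a number 6 percentage points higher from compound 1 to compound 3 (within the scatter) and a number 6 percentage points lower from compound 2 to compound 3 (within the scatter), both within the scatter, and the modest a number 12 percentage points higher from compound 1 to compound 2 (beyond the scatter). All three measured numbers sit high whatever group occupies this carbon, and nothing in them points to a direction for a smaller group. The expected step is therefore none beyond the scatter, a number 9 percentage points lower from compound 3 to compound 4 (within the scatter). Compound 4 is estimated at 85%, with a range from 65% to 100%.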

Compound 4, percent of the compound remaining: 94%
Estimate against measurement, compound 4: 9 percentage points below, and the stated range covers the measured number.
By their numbers in this assay, from the lowest: compounds 1, 3, 4 and 2 (each within the scatter of the next, the first and the last beyond it).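

Working notes, compound 4: In this assay, replacing any of the three ring groups with methyl, on an aromatic carbon para to a large group, gives no step beyond the scatter (no change at the digits printed from compound 3 to compound 4 (within the scatter); a number 6 percentage points higher from compound 1 to compound 4 (within the scatter); a number 6 percentage points lower from compound 2 to compound 4 (within the scatter)). The earlier compounds all carried a ring at this carbon, whereas compound 4 has none, so a ring group here is not needed for a high number in this read-out, at least among these four compounds. For the compounds shown here, compound 4 also lies within the scatter of both compound 1 and compound 2, the one pair separated beyond the scatter, so methyl does not set itself apart from either ring group; nothing available explains why the numbers hold across so large a change in the group at this carbon.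

As far as these compounds go, it remains open whether a group of another kind at this carbon, such as an amine, a carboxylic acid or a longer chain, would leave the number equally high. These compounds also say nothing about a change elsewhere on the shared core, such as replacing the butyl chain with a shorter chain, since all four carry it unchanged.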